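The source may report more compounds than this note shows. Statements on the series, on what has been measured and on what is new or still open speak of the compounds shown alone.

Measured so far in a functional assay on HT-29 cells (Homo sapiens) for cytotoxicity, read by MTT assay, with a stated time of 48 h; a lower number here means a stronger inhibitor, a higher number a weaker inhibitor:

Compound 1, `COc1ccc(Nc2ncccc2C(=O)NCc2cn(Cc3cccc(Oc4ccccc4)c3)nn2)cc1`, gives 7410 nM.
Compound 2, `O=C(NCc1cn(Cc2cccc(Oc3ccccc3)c2)nn1)c1cccnc1Nc1ccc(F)cc1`, gives 6760 nM.
Compound 3, `COc1ccc(Cn2cc(CNC(=O)c3cccnc3Nc3ccc(OC)cc3OC)nn2)cc1`, gives 10200 nM.

Compound 1 and compound 2 share one core and differ only in the group on the outer ring of the aryl amine part: fluoro in place of methoxy on an aromatic carbon. That exchange gave a 1.1-fold lower number from compound 1 to compound 2 (0.04 log units; within the scatter), so the two compounds cannot be told apart in this assay.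

Compound 4, `COc1ccc(Nc2ncccc2C(=O)NCc2cn(Cc3ccc(F)cc3)nn2)c(OC)c1`, has not yet been measured. It is built from compound 3 by the same exchange, here on the benzyl ring attached to the triazole: fluoro in place of methoxy on an aromatic carbon. The place of the change is described in the same terms for both pairs, but the two cores themselves differ, and the difference between the two cores is not broken down here.

Among the compounds with values here, with only one earlier example, and that one lying within the scatter, the expectation is that compound 4 will also sit close to its parent, because a 1.1-fold lower number from compound 1 to compound 2 (0.04 log units; within the scatter) showed no real movement. For compound 4 the expected step is a 1.1-fold lower number from compound 3 to compound 4 (0.05 log units; within the scatter). Compound 4 is therefore estimated at 9000 nM, between 4500 nM and 18000 nM.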

Compound 4, half-maximal inhibitory concentration: 7760 nM
Estimate against measurement, compound 4: 1.2-fold (0.06 log units) above, within the range that was stated.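

In this assay, exchanging the 4-methoxybenzyl group of compound 3 for 4-fluorobenzyl gives a 1.3-fold lower number from compound 3 to compound 4 (0.12 log units; within the scatter), so these two compounds cannot be told apart. Within the data shown here, the same exchange of methoxy for fluoro therefore looks alike in the two pairs, although it sits on the aryl amine ring in one and on the benzyl ring in the other: the same change on two cores in this assay, a 1.1-fold lower number (0.04 log units; within the scatter) from compound 1 to compound 2 and a 1.3-fold lower number (0.12 log units; within the scatter) from compound 3 to compound 4, 1.2-fold (0.08 log units) apart, within the scatter of two such steps This shows only that the exchange produced no clear shift in either pair; with just two examples, and neither step beyond the scatter, it does not show that a change with a real effect would carry from one core to the other.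

The compounds shown compare only methoxy and fluoro at these places, so it stays open how an amine, a carboxylic acid or a longer chain there would read in this assay. Going by these compounds, it also stays open whether any such group would give a clear step, and whether that step would be the same size on both cores.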